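The source may report more compounds than this note shows. Statements on the series, on what has been measured and on what is new or still open speak of the compounds shown alone.

In a functional assay on SK-N-SH cells (Homo sapiens) for inhibition (a lower number here means a stronger inhibitor of growth, a higher number a weaker inhibitor of growth), compound 2 (`O=c1c2cccnc2sn1-c1ccc(Br)cc1`) gives 15200 nM and stands second highest of the three numbers in hand. Compound 1 (`O=c1c2cc([N+](=O)[O-])cnc2sn1-c1ccc(Br)cc1`) gives 53500 nM at the top. Compound 3 (`COc1cccc(-n2sc3ncccc3c2=O)c1`) gives 6990 nM at the bottom, the nearest value to compound 2 and still beyond the scatter from it. The next compound is compound 4 (`CCCCc1ccc(-n2sc3ncccc3c2=O)cc1`), with butyl in place of bromo on an aromatic carbon.

Going by the values given here, the only measured step in one place is a 3.5-fold lower number from compound 1 to compound 2 (0.55 log units; beyond the scatter) and it concerns hydrogen in place of nitro on the shared core, so it gives no direct size for this change. Among the compounds with values here, no measured step replaces the bromo alone. Compound 3 at 6990 nM carries no bromo and sits lower than compound 2 by a modest margin, which is the only hint of direction. A small move toward a lower number in this assay is therefore expected, with wide uncertainty. The estimated step is a 1.5-fold lower number from compound 2 to compound 4 (0.18 log units; within the scatter) and it is expected to stay close to the scatter. For compound 4 the expected value is 10000 nM with 3500 nM to 30000 nM as the estimated range.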

Compound 4, concentration for 50% growth inhibition: 8930 nM
For compound 4 the middle estimate is 1.1-fold (0.05 log units) above the measured one, and the stated range covers the measured number.
By their numbers in this assay, from the lowest: compounds 3, 4 and 2 (each within the scatter of the next, the first and the last beyond it); then compound 1.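

Read directly at this place, on an aromatic carbon of a six-membered aromatic ring of carbon only, para to a large group, butyl in place of bromo in this assay gives a 1.7-fold lower number from compound 2 to compound 4 (0.23 log units; within the scatter). So a single halogen atom and a flexible alkyl chain are not told apart here, and this place accepts the butyl chain with the read-out unchanged within the scatter, unlike the one earlier step, on the shared core, which was a 3.5-fold lower number from compound 1 to compound 2 (0.55 log units; beyond the scatter) and lies beyond the scatter. No measurement on hand gives a reason for this outcome.

Only bromo and butyl are compared at this place, so the pair fixes no trend with chain length and says nothing of how far the chain can grow: a longer chain such as octyl, an amine or a carboxylic acid at the same carbon could each leave the number where it is or shift it beyond the scatter. Also open is whether the step seen for nitro on the shared core would hold the same size with butyl in place of bromo, since that pair of changes appears together in no compound shown.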